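Fluorophenyl swap from compound 3 to compound 4

The compounds below may be only part of what the source reports. "The series", "measured", "known", "first", "only" and "open" are said of these compounds alone.

Of the compounds shown here, three have been read so far in a toxicity assay on Huh-7 cells (Homo sapiens) for cytotoxicity, read by CCK-8 assay, with a stated time of 24 h (a higher number here means that more compound is tolerated, a lower number that less compound is tolerated), and none of them gives a number. Compound 1 (`Cc1ccc(-c2c(O)c(O)c(O)c3c(=O)cc(-c4ccccc4)oc23)cc1`) reads > 100000 nM as a limit of the assay. Compound 2 (`CN1CCN(c2ccc(-c3cc(=O)c4c(O)c(O)c(O)cc4o3)cc2)CC1`) reads > 100000 nM as a limit too. Compound 3 (`Oc1c(O)c(O)c2c(=S)cc(-c3ccccc3)oc2c1-c1ccc(F)cc1`) reads > 100000 nM as a limit as well. Compound 3 therefore stands at the limit of > 100000 nM in this assay, at which 3 of the 3 values shown sit, and has no measured number of its own. Among the measured compounds shown here, the series offers no measured step between compounds that differ in one place.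

Compound 4 (`Oc1c(O)c(O)c2c(=S)cc(-c3ccccc3)oc2c1-c1cccc(F)c1`) carries 3-fluorophenyl in place of 4-fluorophenyl on an aromatic carbon of a six-membered aromatic ring of carbon only. The change counts as 3-fluorophenyl in place of 4-fluorophenyl on an aromatic carbon and leaves the same atoms joined differently.

In this assay no change beyond the scatter is expected, in either direction. This expectation rests on compound 3 at > 100000 nM as a limit. The estimated change is a number no higher from compound 3 to compound 4 (the limit leaves the size open) and is expected to be small. Compound 4 will most likely report only a limit as well. For compound 4 the estimated value is 100000 nM with an expected range from 50000 nM to 200000 nM in the same read-out.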

Compound 4, half-maximal cytotoxic concentration: > 100000 nM
Compound 4 gave a limit, no number; the forecaster's own chance of this, stated with the estimate: 85%; the middle value lies on the limit itself.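

Compound 3 and compound 4 both report only a limit in this assay, so no step can be read for 3-fluorophenyl in place of 4-fluorophenyl: the limit of > 100000 nM in this assay, at which 4 of the 4 values shown sit. The compounds shown leave open at what concentration any of them becomes cytotoxic to these cells, and whether 3-fluorophenyl and 4-fluorophenyl differ at all in this respect.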